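Swapping a benzyl for a pyrimidine on the ring nitrogen

A few compounds are considered here, and "the series" means these few. Any claim that something is new, unique, unknown or untested is made for them only; others in the source may bear on it.

Of the compounds shown here, three sharing one core have been measured in an assay on HEK293 cells for inhibition of Steryl-sulfatase (Homo sapiens), tested at 1 uM; on this read-out higher numbers stand for a stronger effect at the one concentration tested and lower numbers for a weaker effect. Compound 1 `NS(=O)(=O)Oc1ccc2c(c1)CN(C(=O)c1cccc(N(Cc3ccccc3)Cc3ccco3)c1)CC2` gives 90.5% in this assay. Compound 3 `CC(C)CCN(CCC(C)C)c1ccc(C(=O)N2CCc3ccc(OS(N)(=O)=O)cc3C2)cc1` gives 90.8%. Compound 2 `NS(=O)(=O)Oc1ccc2c(c1)CN(C(=O)c1ccc(N3CCN(Cc4ccccc4)CC3)cc1)CC2` gives 75.8%, the lowest of the three numbers; its gap to compound 1 and to compound 3 lies beyond the usual scatter in each case, so compound 2 is the weakest of the three at the single concentration tested.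

The unmeasured compound 4 `NS(=O)(=O)Oc1ccc2c(c1)CN(C(=O)c1ccc(N3CCN(c4ncccn4)CC3)cc1)CC2` differs from compound 2 in a single spot: pyrimidin-2-yl in place of benzyl on an amine nitrogen in a ring. Within the data shown here, no other pair among the measured compounds differs in just one place, so there is no measured step to lean on for this exchange.

Without such a reference, only a modest step is expected from compound 2 to compound 4 in this assay, of the order of the scatter itself or slightly downward, rather than a clear gain. The value of compound 4 is therefore estimated at 72%, within a range from 50% to 88%, which means an expected step of a number 3.8 percentage points lower from compound 2 to compound 4 (within the scatter).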

Compound 4, a percentage reported as inhibition, at one concentration (the size of the read-out at that concentration, not a potency) in the Steryl-sulfatase assay: 41.9%
For compound 4 the middle estimate is 30.1 percentage points above the measured one; measured number outside the range, below it.
By their numbers in the Steryl-sulfatase assay, from the lowest: compound 4; then compound 2; then compounds 1 and 3 (each within the scatter of the next).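

Among these compounds, in the Steryl-sulfatase assay, the exchange of benzyl for pyrimidin-2-yl on this amine nitrogen in a ring gives the first step that can be read, and it is large: a number 33.9 percentage points lower from compound 2 to compound 4 (beyond the scatter), with compound 2 at 75.8% and compound 4 at 41.9%. This position therefore responds strongly to the group it carries, even though both groups contain a six-membered aromatic ring. In a physicochemical assay for lipophilicity (a higher number here means a more lipophilic compound, a lower number a more polar compound), the same exchange gives no change at the digits printed from compound 2 to compound 4 (within the scatter), with compound 2 at 1.93 and compound 4 at 1.93, so the drop in the Steryl-sulfatase assay appears with no measurable shift in this partition coefficient.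

Nothing available here explains the drop. The exchange alters two things at once, the carbon link of the benzyl and the ring's two nitrogens, and a phenyl group on the same nitrogen would be needed to tell their contributions apart.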